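This account rests on a few compounds, and the source may have more. Where it says the series, first, only, none or still open, it means among the compounds named here.

For the measured compounds named here, compound 1, with structure `COc1ccccc1-c1cnc(C(=O)CCCCCCc2ccccc2)o1`, is one of three compounds measured in an assay (Rattus norvegicus) for inhibition of Fatty-acid amide hydrolase 1 (Homo sapiens); a lower number here means a stronger inhibitor, a higher number a weaker inhibitor. There compound 1 gives 400 nM, which places it second highest of the three numbers. Compound 2, `O=C(CCCCCCc1ccccc1)c1ncc(-c2ccccc2C(=O)C(F)(F)F)o1`, gives 5000 nM, and compound 3, `O=C(CCCCCCc1ccccc1)c1ncc(-c2cccc(C(=O)C(F)(F)F)c2)o1`, gives 16 nM.

The unmeasured compound 4 has structure `O=C(CCCCCCc1ccccc1)c1ncc(-c2ccc(F)cc2)o1`. It differs from compound 1 in a single place: 4-fluorophenyl in place of 2-methoxyphenyl on an aromatic carbon.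

Going by the values given here, only one measured step touches the same position, namely the one from compound 1 to compound 2, where a (trifluoromethyl)carbonyl replaces the methoxy on that aromatic carbon and the number rises a 13-fold higher number from compound 1 to compound 2 (1.10 log units; beyond the scatter). That step shows the group on this aromatic carbon matters, but it exchanges methoxy for a larger group, whereas compound 4 exchanges the whole 2-methoxyphenyl for a 4-fluorophenyl. Compound 3 carries a (trifluoromethyl)carbonyl elsewhere on the phenyl and stands far lower than compound 2, so the two values alone suggest the outcome depends strongly on where the group sits. Among the compounds with values here, no measured compound carries a fluorine, so the direction for compound 4 is open. Compound 4 is therefore expected to stay near compound 1, with an estimated step of a 1.3-fold lower number from compound 1 to compound 4 (0.12 log units; within the scatter), and an estimated value of 300 nM in a range from 80 nM to 1200 nM.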

Compound 4, inhibition constant: 62 nM
Beside the measured number, compound 4's estimate is 4.8-fold (0.68 log units) above it; measured number below the stated range.
By their numbers in this assay, from the lowest: compound 3; then compound 4; then compound 1; then compound 2.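

In this assay the exchange of 2-methoxyphenyl for 4-fluorophenyl on the aromatic carbon next to the ring oxygen gives a 6.5-fold lower number from compound 1 to compound 4 (0.81 log units; beyond the scatter) and so shows that the 2-methoxyphenyl is not required for a number lower than that of compound 1. For the compounds shown here, the only earlier step at this place, a 13-fold higher number from compound 1 to compound 2 (1.10 log units; beyond the scatter) and thus upward, replaced just the methoxy, so the series now holds changes on this aryl group that move the number in opposite directions beyond the scatter. Nothing given here offers an explanation for the lower number of compound 4.

The step from compound 1 to compound 4 removes a methoxy and adds a fluorine on a different ring carbon in a single exchange, so the shares of the lost methoxy, the added fluorine and the new location in the result cannot be separated. A plain phenyl, a 2-fluorophenyl and a 4-methoxyphenyl at this place would divide that exchange into its parts, while a 4-chlorophenyl would test whether another halogen at the same ring carbon gives a similar number.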